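The source may report more compounds than this note shows. Statements on the series, on what has been measured and on what is new or still open speak of the compounds shown alone.

Three compounds of one shared core have been run in a functional assay, with a stated time of 30 min, tested at 20 uM; on this read-out lower numbers stand for less inhibition and higher numbers for more inhibition at the one concentration tested (going by the name of the read-out): compound 1 `c1ccc(-c2nnc(Nc3ncccn3)o2)cc1` gives 51.4%, compound 2 `Oc1ccccc1-c1nnc(Nc2ncccn2)o1` gives 58.8% and compound 3 `c1cnc(Nc2nnc(-c3cccc4ccccc34)o2)nc1` gives 60%. The number of compound 2 is the second highest of the three, with compound 3 nearest and compound 1 furthest, both gaps within the scatter. Among the compounds with values here, the one single-point step so far, a number 7.4 percentage points higher from compound 1 to compound 2 (within the scatter), also lies within the scatter. Compound 4 `Clc1ccccc1-c1nnc(Nc2ncccn2)o1` is not yet measured; it differs from compound 2 in that (chloro in place of hydroxy on an aromatic carbon). Within the data shown here, no measured step brings chloro in, and the only step at this place, a number 7.4 percentage points higher from compound 1 to compound 2 (within the scatter), stayed within the scatter, so no step beyond the scatter is expected. For compound 4 the estimate in this assay is 55%, between 40% and 70%, an expected step of a number 3.8 percentage points lower from compound 2 to compound 4 (within the scatter).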

Compound 4, a percentage reported as inhibition, at one concentration (the size of the read-out at that concentration, not a potency): < 20%
Compound 4 ended at the assay's limit (the forecaster's own chance of this, stated with the estimate: 0%); middle value at least 35 percentage points away from the limit.
By their numbers in this assay, from the lowest: compounds 1, 2 and 3 (each within the scatter of the next). At a limit, below all of these: compound 4.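

Until now this position, on the aromatic ring and ortho to a large group, had given only a step within the scatter, but chloro changes that in this assay: a number at least 38.8 percentage points lower from compound 2 to compound 4 (beyond the scatter). The change is just as clear against hydrogen, so the loss goes with chloro entering and not only with hydroxy leaving: a number at least 31.4 percentage points lower from compound 1 to compound 4 (beyond the scatter). Compound 4 gives a limit of the assay, < 20%, and not a number.

On these data alone, how far compound 4 truly lies past that limit stays open. Also open, as far as these compounds go, is whether an amine or a methoxy group at this place would follow hydroxy or chloro.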